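Cytotoxicity in MT4 cells across a small triazine series

This account rests on a few compounds, and the source may have more. Where it says the series, first, only, none or still open, it means among the compounds named here.

Compound 1 `CNc1nc(Nc2ccc(C#N)cc2)nc(Oc2cccc3ccccc23)n1`: 30300 nM
Compound 2 `N#Cc1ccc(Nc2nc(N)nc(Oc3cccc4ccccc34)n2)cc1`: 39100 nM
Compound 3 `CNc1nc(Nc2ccc(C#N)cc2)nc(Oc2ccc3ccccc3c2Br)n1`: 143000 nM

Of the compounds shown here, three have been measured in an ADME assay on MT4 cells (Homo sapiens) for cytotoxicity, read by MTT assay, with a stated time of 4 days; on this read-out higher numbers stand for lower toxicity in this test and lower numbers for higher toxicity in this test. Compound 1 `CNc1nc(Nc2ccc(C#N)cc2)nc(Oc2cccc3ccccc23)n1` gives 30300 nM in this assay, and compound 2 `N#Cc1ccc(Nc2nc(N)nc(Oc3cccc4ccccc34)n2)cc1` gives 39100 nM. The change between them, (hydrogen in place of methyl on a nitrogen on an aromatic ring), made a step of a 1.3-fold higher number from compound 1 to compound 2 (0.11 log units; within the scatter). Compound 3 `CNc1nc(Nc2ccc(C#N)cc2)nc(Oc2ccc3ccccc3c2Br)n1` gives 143000 nM in this assay; the difference between the core of compound 3 and the core of compound 1 is not broken down here.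

Compound 4 `N#Cc1ccc(Nc2nc(N)nc(Oc3ccc4ccccc4c3Br)n2)cc1` is not yet measured. It differs from compound 3 by hydrogen in place of methyl on a nitrogen on an aromatic ring, the same change as between compound 1 and compound 2, at a place described in the same words. Because the earlier step was a 1.3-fold higher number from compound 1 to compound 2 (0.11 log units; within the scatter), a similarly small step a 1.1-fold higher number from compound 3 to compound 4 (0.05 log units; within the scatter) is expected in this assay. Compound 4 is therefore estimated at 160000 nM, with a likely range from 80000 nM to 320000 nM.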

Compound 4, half-maximal cytotoxic concentration: 133000 nM
Compound 4: the middle estimate sits 1.2-fold (0.08 log units) above what was measured; measured number inside the range.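

In this assay the change from methylamino to amino gave a 1.1-fold lower number from compound 3 to compound 4 (0.03 log units; within the scatter) on this second core. Set beside the earlier step, the change reads alike on both cores: the same change on two cores in this assay, a 1.3-fold higher number (0.11 log units; within the scatter) from compound 1 to compound 2 and a 1.1-fold lower number (0.03 log units; within the scatter) from compound 3 to compound 4, 1.4-fold (0.14 log units) apart, within the scatter of two such steps. This shows that on these two cores, one without and one with bromine, swapping methyl for hydrogen on that nitrogen left the number within the scatter, but two pairs do not show that the same would hold on any other core in the series.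

The compounds shown leave open whether a longer chain such as ethyl, or a cyclic amine such as morpholine, at that nitrogen would read alike on both cores. They also leave open how either core would respond to a carboxylic acid there.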